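The source may report more compounds than this note shows. Statements on the series, on what has been measured and on what is new or still open speak of the compounds shown alone.

Measured compounds:
compound 1, `CCn1c(CNc2ccccc2)nnc1SCC(=O)Nc1ccc(C(=O)OC)cc1`, 540 nM
compound 2, `CCn1c(CNc2ccccc2)nnc1SCc1nc2cc(Cl)ccc2o1`, > 1000 nM
compound 3, `CCn1c(CNc2ccccc2)nnc1SCc1nc2cc(C)ccc2o1`, > 1000 nM

Within the data shown here, in an assay on isolated protein for inhibition of long-chain fatty acid transport protein 1 (Homo sapiens) (on this read-out higher numbers stand for weaker inhibition and lower numbers for stronger inhibition), compound 1 gives 540 nM, the only number among the three values shown. Compound 2 gives > 1000 nM, which is a limit of the assay rather than a number. Compound 3 likewise gives > 1000 nM, again a limit. The step that the two limits leave unreadable from compound 2 to compound 3 therefore cannot be read. Compound 4, `CCn1c(CNc2ccccc2)nnc1SCC(=O)Nc1ccccc1`, differs from compound 1 by hydrogen in place of methoxycarbonyl on an aromatic carbon. No measured step touches this part of the core, so nothing shown predicts the direction; the only pointer is the limit of > 1000 nM in this assay, at which 2 of the 3 values shown sit. Compound 4 is expected to sit near 900 nM, within 350 nM to 3000 nM. The step of a 1.7-fold higher number from compound 1 to compound 4 (0.22 log units; within the scatter) is thus estimated as a mild loss, not clearly beyond the scatter.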

Compound 4, half-maximal inhibitory concentration: > 1000 nM
Compound 4 ended at the assay's limit; the forecaster's own chance of this, stated with the estimate: 40%; at least 1.1-fold (0.04 log units) between middle value and limit.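

In this assay compound 4 gives > 1000 nM, which is a limit of the assay and not a number. Replacing the methoxycarbonyl with hydrogen gives an at least 1.8-fold higher number from compound 1 to compound 4 (0.26 log units; that floor lies within the scatter), the first step shown at this position of the aromatic ring, though its floor alone does not establish a real loss. The result adds one more compound to those at the limit: the limit of > 1000 nM in this assay, at which 3 of the 4 values shown sit.

From the compounds shown here alone, it remains open how large the step really is and whether the methoxycarbonyl itself matters. A carboxylic acid or a methoxy group on the same aromatic carbon would test that question.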